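Working notes: from compound 3 to compound 4

The compounds below may be only part of what the source reports. "The series", "measured", "known", "first", "only" and "open" are said of these compounds alone.

In an ADME assay on Vero cells (Chlorocebus sabaeus) for cytotoxicity, read by MTT assay, with a stated time of 72 h (a higher number here means that more compound is tolerated, a lower number that less compound is tolerated), compound 3 (`CO/N=C(\C)CN1CCN(c2c(F)cc3c(=O)c(C(=O)O)cn(C4CC4)c3c2OC)CC1C`) gives 49.6 ug/mL as the lower of the two actual numbers in the series. Compound 1 (`COc1c(N2CCN(CC#N)C(C)C2)c(F)cc2c(=O)c(C(=O)O)cn(C3CC3)c12`) gives 354 ug/mL as its nearest neighbour. Compound 2 (`COC(=O)CCN1CCN(c2c(F)cc3c(=O)c(C(=O)O)cn(C4CC4)c3c2OC)CC1C`) gives > 1000 ug/mL as a limit of the assay and not a number.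

Compound 4 (`COc1c(N2CCN(C/C(C)=N/Nc3ccccc3)C(C)C2)c(F)cc2c(=O)c(C(=O)O)cn(C3CC3)c12`) has anilino in place of methoxy on a double-bonded nitrogen. The measured steps all change the group on a saturated chain carbon bound to an amine nitrogen in a ring, and none isolates this exchange. A larger group gives a 7.1-fold lower number from compound 1 to compound 3 (0.85 log units; beyond the scatter) in one case. Compound 2 goes against any simple size trend, with an at least 2.8-fold higher number from compound 1 to compound 2 (0.45 log units; beyond the scatter) as the step. Two groups of equal count also differ widely, with an at least 20-fold lower number from compound 2 to compound 3 (1.30 log units; beyond the scatter) as the step.

These steps set no direction for the new exchange, so compound 3 at 49.6 ug/mL serves as the anchor. No step beyond the scatter is expected, with a slight lean to a lower number. The expected step is a 1.7-fold lower number from compound 3 to compound 4 (0.22 log units; within the scatter) in this assay as an estimate only. For compound 4 the estimated value is 30 ug/mL with an expected range of 8 ug/mL to 150 ug/mL on this basis.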

Compound 4, half-maximal cytotoxic concentration: 11.1 ug/mL
Beside the measured number, compound 4's estimate is 2.7-fold (0.43 log units) above it, within the range that was stated.
By their numbers in this assay, from the lowest: compound 4; then compound 3; then compound 1. At a limit, above all of these: compound 2.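

In this assay, within the data shown here, the exchange of anilino for methoxy on a double-bonded nitrogen gives a 4.5-fold lower number from compound 3 to compound 4 (0.65 log units; beyond the scatter), so this position, which no earlier step isolated, does respond to the group it carries. Across the whole group on the saturated chain carbon, the change from compound 1 gives a 32-fold lower number from compound 1 to compound 4 (1.50 log units; beyond the scatter), which places compound 4 lowest in the series, with steps beyond the scatter to compound 1 and compound 3. Compound 2 stands at a limit and not a number, so an at least 90-fold lower number from compound 2 to compound 4 (1.95 log units; beyond the scatter) is a bound and not a measured size: the limit of > 1000 ug/mL in this assay, at which 1 of the 4 values shown sits.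

The exchange brings in the six-membered aromatic ring and the nitrogen that links it together, so the compounds shown cannot say which of the two goes with the lower number; benzyloxy on the same double-bonded nitrogen would keep the ring without that linking nitrogen, and a plain amine or hydroxy there would test the linking atom without the ring. On these data alone, whether a substituted anilino, such as one carrying a carboxylic acid on its ring, moves the number in either direction also remains open.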